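The compounds below may be only part of what the source reports. "The series", "measured", "known", "first", "only" and "open" are said of these compounds alone.

Measured so far in a functional assay on HepG2 cells (Homo sapiens) for antiproliferative activity, read by sulforhodamine B assay, with a stated time of 48 h; on this read-out higher numbers stand for weaker inhibition and lower numbers for stronger inhibition 
- compound 1 `COc1ccc(OC)c(/C=C/C(=O)C(=Cc2cc(OC)c(O)c(OC)c2)C(=O)/C=C/c2cc(OC)ccc2OC)c1` at 210 nM 
- compound 2 `COc1ccc(/C=C/C(=O)C(=Cc2ccc(O)c(OC)c2)C(=O)/C=C/c2ccc(OC)cc2OC)c(OC)c1` at 510 nM 

Compound 2 holds the higher of the two numbers, and compound 1 lies lower by a gap beyond the usual scatter. For the measured compounds named here, the two compounds differ in more than one place, so no single-place step has been measured yet.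

Next in line is compound 3 `COc1ccc(/C=C/C(=O)C(=Cc2cc(OC)c(O)c(OC)c2)C(=O)/C=C/c2ccc(OC)cc2OC)c(OC)c1`, which differs from compound 2 by a methoxy in place of hydrogen on an aromatic carbon. This turns the 4-hydroxy-3-methoxyphenyl into 4-hydroxy-3,5-dimethoxyphenyl. Going by the values given here, the only guide is compound 1 (210 nM), which also carries the 4-hydroxy-3,5-dimethoxyphenyl group, although its other groups are not those of compound 3. A small move towards a lower number in this assay is therefore expected, possibly no larger than the scatter. The expected change is a 1.6-fold lower number from compound 2 to compound 3 (0.20 log units; within the scatter) and rests on thin evidence. For compound 3 the estimated value is 320 nM (expected range 130 nM to 750 nM) pending measurement.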

Compound 3, half-maximal inhibitory concentration: 320 nM
Estimate against measurement, compound 3: no gap at the digits printed; low and high end bracket the measured number.
By their numbers in this assay, from the lowest: compounds 1, 3 and 2 (each within the scatter of the next, the first and the last beyond it).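

In this assay, for the compounds shown here, the first single-place step puts a methoxy in place of hydrogen on an aromatic carbon, ortho to the hydroxy group, turning 4-hydroxy-3-methoxyphenyl into 4-hydroxy-3,5-dimethoxyphenyl, and it reads a 1.6-fold lower number from compound 2 to compound 3 (0.20 log units; within the scatter). At this position, then, the added methoxy leaves the read-out within the scatter: the pair cannot be told apart in this assay, and a second methoxy flanking the hydroxy group is accommodated without a loss that the data can resolve. No measurement of any property of these groups accompanies the step, and the data offer no account of it.

Only hydrogen and methoxy are shown at this place, and how an ethoxy, an amine or a carboxylic acid there would read in this assay remains open. All three compounds shown also keep the hydroxy group on this ring, leaving open what a methoxy or an amine in its stead would do, and whether the flat response to the added methoxy holds with other groups on the rest of the core.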